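Swapping the Aryl Substituent in a Diaryl Alkyne Series

This account rests on a few compounds, and the source may have more. Where it says the series, first, only, none or still open, it means among the compounds named here.

Compound 1 `CCCS(=O)(=O)c1cccc(C#Cc2cc(Cl)ccc2OCC(=O)O)c1`: 9 nM
Compound 2 `CN(C)C(=O)c1cccc(C#Cc2cc(Cl)ccc2OCC(=O)O)c1`: 52 nM

Two measured compounds share one core and differ only in the group on the outer aromatic ring. In an assay on CHO cells for displacement of a labelled ligand from prostaglandin D2 receptor 2 (Homo sapiens), read by scintillation counting (on this read-out lower numbers stand for stronger inhibition and higher numbers for weaker inhibition), compound 1 gives 9 nM. Compound 2 gives 52 nM in this assay. Compound 2 therefore stands highest of the two numbers shown, and the single measured step, a 5.8-fold higher number from compound 1 to compound 2 (0.76 log units; beyond the scatter), tells how far the exchange of that one group moved the read-out.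

Compound 3 `O=C(O)COc1ccc(Cl)cc1C#Cc1cccc(C(F)(F)F)c1` is not yet measured. It differs from compound 2 as follows: trifluoromethyl in place of dimethylcarbamoyl on an aromatic carbon. For the measured compounds named here, no measured pair exchanges a group for trifluoromethyl, so the only step that bears on this change is a 5.8-fold higher number from compound 1 to compound 2 (0.76 log units; beyond the scatter); it shows that replacing the group at this position shifts the number by a modest amount, beyond the scatter, in one direction or the other. A modest step is therefore expected for compound 3 as well, most likely towards a lower number, so that the step from compound 2 is estimated as a 1.7-fold lower number from compound 2 to compound 3 (0.24 log units; within the scatter). For compound 3 the estimate in this assay is 30 nM, with a range from 8 nM to 120 nM.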

Compound 3, inhibition constant: 92 nM
Compound 3: the middle estimate sits 3.1-fold (0.49 log units) below what was measured, and the stated range covers the measured number.
By their numbers in this assay, from the lowest: compound 1; then compounds 2 and 3 (each within the scatter of the next).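

In this assay, the exchange at this position gives a 1.8-fold higher number from compound 2 to compound 3 (0.25 log units; within the scatter) and so does not separate trifluoromethyl from dimethylcarbamoyl, even though dimethylcarbamoyl counts 1 hydrogen-bond acceptor and trifluoromethyl counts 0. The comparison with propylsulfonyl gives a 10-fold higher number from compound 1 to compound 3 (1.01 log units; beyond the scatter) and is the largest step shown, so among these three groups, propylsulfonyl alone stands apart, with a lower number beyond the scatter against each of the other two. Nothing on hand accounts for this separation.

The compounds shown leave open whether the lower number of compound 1 depends on the sulfonyl unit or on its propyl chain, a question that a methylsulfonyl group, a longer alkyl sulfonyl group or a plain propyl group at the same place would address. They also leave open how a sulfonamide, a nitrile or an amine would compare at this position, and whether the order seen here would hold with a different substituent in place of the chlorine on the shared core.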